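The source may report more compounds than this note shows. Statements on the series, on what has been measured and on what is new or still open speak of the compounds shown alone.

Measured so far in a functional assay on brain (Rattus norvegicus, strain Wistar) for inhibition; on this read-out lower numbers stand for stronger inhibition and higher numbers for weaker inhibition:

- Compound 1 `CCCCCOc1ccc(-c2c(C)[nH]c(=O)n2C2CCCCC2)cc1`: 9100 nM
- Compound 2 `Cc1[nH]c(=O)n(C2CCCCC2)c1-c1ccc(C2CCCCC2)cc1`: 28900 nM
- Compound 3 `CCCCCCCOc1ccc(-c2c(C)[nH]c(=O)n2C2CCCCC2)cc1`: 11600 nM

Compound 3 stands within the scatter of compound 1, and both numbers are lower than that of compound 2. The next structure, compound 4 `Cc1[nH]c(=O)n(C2CCCCC2)c1-c1ccc(-c2ccccc2)cc1`, carries one change: phenyl in place of heptyloxy on an aromatic carbon. The nearest guide is cyclohexyl in place of pentyloxy, which gave a 3.2-fold higher number from compound 1 to compound 2 (0.50 log units; beyond the scatter). The reverse kind of swap, heptyloxy in place of cyclohexyl, gave a 2.5-fold lower number from compound 2 to compound 3 (0.40 log units; beyond the scatter). Chain length alone gave a 1.3-fold higher number from compound 1 to compound 3 (0.11 log units; within the scatter). Phenyl itself has not been measured here, so a modest rise in this assay is only an expectation. The expected step is a 2.2-fold higher number from compound 3 to compound 4 (0.33 log units; beyond the scatter). The estimate for compound 4 is 25000 nM, with an expected range from 10000 nM to 60000 nM.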

Compound 4, half-maximal inhibitory concentration: 10900 nM
Estimate against measurement, compound 4: 2.3-fold (0.36 log units) above; measured number inside the range.
By their numbers in this assay, from the lowest: compounds 1, 4 and 3 (each within the scatter of the next); then compound 2.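

In this assay, phenyl at this aromatic carbon matches the two ether chains, giving a 1.1-fold lower number from compound 3 to compound 4 (0.03 log units; within the scatter) and a 1.2-fold higher number from compound 1 to compound 4 (0.08 log units; within the scatter), whereas phenyl in place of cyclohexyl gives a 2.7-fold lower number from compound 2 to compound 4 (0.42 log units; beyond the scatter). Thus a group with no hydrogen-bond acceptor and no chain serves as well here as pentyloxy or heptyloxy, and among these four compounds only the cyclohexyl compound stands apart. Nothing available explains why phenyl and cyclohexyl differ. From the compounds shown here alone, whether a pyridyl ring or a carboxylic acid at this carbon would move the number beyond the scatter remains open.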